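A methoxybenzyl for a dichlorobenzyl on a shared core

The source may report more compounds than this note shows. Statements on the series, on what has been measured and on what is new or still open speak of the compounds shown alone.

Compound 1 `CC(C)(C)OC(=O)N1CCN(C(=S)SCc2cn(-c3ccccc3F)nn2)CC1` gives > 128000 nM in a functional assay on PC-3 cells (Homo sapiens) for inhibition, read by MTT assay, with a stated time of 72 h (on this read-out lower numbers stand for stronger inhibition and higher numbers for weaker inhibition), a limit of the assay.
Compound 2 `CC(C)(C)OC(=O)N1CCN(C(=S)SCc2cn(Cc3ccc(Cl)c(Cl)c3)nn2)CC1` gives > 128000 nM in this assay, likewise a limit.

Compound 2 thus stands only at a limit in this assay, and nothing more than that is known of it. Going by the values given here, the one measured step, a step that the two limits leave unreadable from compound 1 to compound 2, cannot be read, because the limit of > 128000 nM in this assay, at which 2 of the 2 values shown sit, holds both of its ends. Compound 3 `COc1ccc(Cn2cc(CSC(=S)N3CCN(C(=O)OC(C)(C)C)CC3)nn2)cc1` differs from compound 2 by 4-methoxyphenyl in place of 3,4-dichlorophenyl on a saturated chain carbon bound to an aromatic nitrogen. Among the compounds with values here, no measured step touches this change, and the single step that exists gives no size at all, so nothing in the data argues for a move in either direction beyond the scatter. Compound 3 is therefore expected to give about 150000 nM in this assay, between 30000 nM and 700000 nM, most likely again reported as a limit. The expected step, a step that the limit leaves unreadable from compound 2 to compound 3, is estimated to lie within the scatter.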

Compound 3, half-maximal inhibitory concentration: > 128000 nM
Compound 3 gave a limit, no number; the forecaster's own chance of this, stated with the estimate: 80%; the middle value does not contradict the limit.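

Going by these compounds alone, no step between compound 1, compound 2 and compound 3 can be read in this assay, because all three values sit at the same point: the limit of > 128000 nM in this assay, at which 3 of the 3 values shown sit. From the compounds shown here alone, whether the group on the shared core affects inhibition at all, and in which direction, remains open.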